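Amide chain trimming on the shared core

The source may hold more compounds than are shown below. What is called first, only, known or untested is meant among the compounds shown, and "the series" means these compounds.

Compound 1 `CC(C)CCC(=O)Nc1ccn([C@H]2CC[C@H](O)[C@@H](C)O2)c(=O)n1`, compound 2 `CC(C)=CCC(=O)Nc1ccn([C@H]2CC[C@H](O)[C@@H](C)O2)c(=O)n1` and compound 3 `CC(C)C(=O)Nc1ccn([C@H]2CC[C@H](O)[C@@H](C)O2)c(=O)n1` carry the same core and differ only in the acyl group on the amide. In a functional assay on HCT-116 cells (Homo sapiens) for cytotoxicity, read by sulforhodamine B assay, with a stated time of 24 h (on this read-out higher numbers stand for weaker inhibition and lower numbers for stronger inhibition), compound 1 gives > 20000 nM, which is a limit of the assay and not a number. In this assay compound 2 gives > 20000 nM, again a limit. In this assay compound 3 gives > 20000 nM, also a limit. Compound 3 therefore stands at the limit of > 20000 nM in this assay, at which 3 of the 3 values shown sit, and its steps a step that the two limits leave unreadable from compound 1 to compound 3 and a step that the two limits leave unreadable from compound 2 to compound 3, like the step that the two limits leave unreadable from compound 1 to compound 2, cannot be read in size or direction.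

Compound 4 `CCC(=O)Nc1ccn([C@H]2CC[C@H](O)[C@@H](C)O2)c(=O)n1` is the next member. The change from compound 3 to compound 4 is hydrogen in place of methyl on a saturated chain carbon bound to a carbonyl carbon and a saturated chain carbon. All three measured steps alter the same acyl group, yet none of them has a readable size, so none points to a direction for this smaller change. The working expectation is that compound 4 also ends at the limit, which means an expected step that the limit leaves unreadable from compound 3 to compound 4. In this assay compound 4 is estimated at 25000 nM, with an expected range from 10000 nM to 60000 nM.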

Compound 4, half-maximal inhibitory concentration: > 20000 nM
Compound 4: only a limit was reported (the forecaster's own chance of this, stated with the estimate: 85%); the middle value does not contradict the limit.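

In this assay compound 4 gives > 20000 nM, which is a limit and not a number. Going by these compounds alone, no step among compound 1, compound 2, compound 3 and compound 4 can be read in size or direction. The compounds shown leave open whether any acyl group on the shared core gives a measurable value: the limit of > 20000 nM in this assay, at which 4 of the 4 values shown sit.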